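A few compounds are considered here, and "the series" means these few. Any claim that something is new, unique, unknown or untested is made for them only; others in the source may bear on it.

Going by the values given here, in an ADME assay on microsomes from liver (Homo sapiens) for metabolic stability, read by LC-MS, using NADPH, with stated times of 5 min and 30 min, tested at 1 uM (a lower number here means slower removal, a higher number faster removal of the compound), compound 2 `CNC(=O)c1ccc(-c2cnc(NCc3c(F)ccc4c3CCO4)c3cn[nH]c(=O)c23)c(C)n1` gives 23 mL.min-1.g-1, the only exact number so far. Among the compounds with values here, its one comparison is compound 1 `CNC(=O)c1cc(-c2cnc(NCc3c(F)ccc4c3CCO4)c3cn[nH]c(=O)c23)n(C)n1`. Compound 1 reads < 3 mL.min-1.g-1, which is a limit of the assay and not a number.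

Compound 3 `CN(c1ccn(C)n1)c1cnc(NCc2c(F)ccc3c2CCO3)c2cn[nH]c(=O)c12` keeps the shared core but carries methyl(1-methyl-1H-pyrazol-3-yl)amino in place of 2-methyl-6-(methylcarbamoyl)pyridin-3-yl on an aromatic carbon. Within the data shown here, only one measured step bears on this change. That step is an at least 7.6-fold higher number from compound 1 to compound 2 (0.88 log units; beyond the scatter), which lies beyond the scatter and came with 2-methyl-6-(methylcarbamoyl)pyridin-3-yl replacing 1-methyl-3-(methylcarbamoyl)-1H-pyrazol-5-yl. Compound 3 also gives up that pyridine group and has a methylated pyrazole, although it is attached through a nitrogen and lacks the methylcarbamoyl group of compound 1. This single step is therefore only a loose guide, but it points to a lower number in this assay. The expected change is a 2.9-fold lower number from compound 2 to compound 3 (0.46 log units; beyond the scatter), a step smaller than the measured one. For compound 3 the estimated value is 8 mL.min-1.g-1, with an expected range from 3 mL.min-1.g-1 to 25 mL.min-1.g-1.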

Compound 3, intrinsic clearance in microsomes: 62 mL.min-1.g-1
Compound 3: middle estimate off by 7.8-fold (0.89 log units), on the low side; the whole stated range lies below it.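

Compound 3 shows that giving up the pyridine group at this position does not by itself lower the number in this assay: the swap to methyl(1-methyl-1H-pyrazol-3-yl)amino brings a 2.7-fold higher number from compound 2 to compound 3 (0.43 log units; beyond the scatter). A methylated pyrazole at this place therefore does not guarantee slow removal, since the swap from 1-methyl-3-(methylcarbamoyl)-1H-pyrazol-5-yl to the nitrogen-linked pyrazole brings an at least 20-fold higher number from compound 1 to compound 3 (1.31 log units; beyond the scatter). From the compounds shown here alone, compound 1 stands at a limit of the assay and not a number, so the true size of that step stays open: the limit of < 3 mL.min-1.g-1 in this assay, at which 1 of the 3 values shown sits.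

The step from compound 1 to compound 3 changes two things within one group, the link to the core through a nitrogen and the loss of the methylcarbamoyl group, and the compounds shown do not separate these two changes. A 1-methyl-1H-pyrazol-3-yl group joined directly to the core, or the methyl(1-methyl-1H-pyrazol-3-yl)amino group with a primary amide added to its pyrazole, would help show which of the two goes with the higher number.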